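Benzoyl in place of hydroxyl hydrogen on two cores

This account rests on a few compounds, and the source may have more. Where it says the series, first, only, none or still open, it means among the compounds named here.

Compound 1 `OC1CCCCC1n1cc(CN2CCN(c3ccccc3)CC2)nn1` is the reference on the first core. In an assay on nucleic acid for inhibition of Nucleic Acid, read by fluorescence, tested at 100 uM (a lower number here means less inhibition, a higher number more inhibition at the concentration tested (going by the name of the read-out)), compound 1 gives 47%. Compound 3 `O=C(OC1CCCCC1n1cc(CN2CCN(c3ccccc3)CC2)nn1)c1ccccc1` carries benzoyl in place of hydrogen on an oxygen on a saturated carbon; in this assay compound 3 gives 21%, and the step of a number 26 percentage points lower from compound 1 to compound 3 (beyond the scatter). Compound 2 `CCOC(=O)C1CCCN(Cc2cn(C3CCCCC3O)nn2)C1` stands on a second core; the difference between the two cores is not broken down here. In this assay compound 2 gives 16%, a number within the scatter of compound 3 and beyond the scatter of compound 1. Compound 4 `CCOC(=O)C1CCCN(Cc2cn(C3CCCCC3OC(=O)c3ccccc3)nn2)C1` is not yet measured and carries benzoyl in place of hydrogen on an oxygen on a saturated carbon, the same change as that from compound 1 to compound 3, at the same place on the second core. The step is expected to be a number 11 percentage points lower from compound 2 to compound 4 (beyond the scatter), smaller than the earlier one, because compound 2 starts from 16% and the read-out has little room left to fall. Compound 4 is therefore expected to give 5% in this assay, between -10% and 20%.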

Compound 4, a percentage reported as inhibition, at one concentration (the size of the read-out at that concentration, not a potency): 11%
For compound 4 the middle estimate is 6 percentage points below the measured one, and the stated range covers the measured number.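

In this assay, benzoyl in place of hydrogen on the oxygen does not carry over at the same size from the core of compound 1 to the core of compound 2: the same change on two cores in this assay, a number 26 percentage points lower (beyond the scatter) from compound 1 to compound 3 and a number 5 percentage points lower (within the scatter) from compound 2 to compound 4, 21 percentage points apart, beyond the scatter of two such steps

On the second core the step reads a number 5 percentage points lower from compound 2 to compound 4 (within the scatter), so the change leaves no readable difference there, and a size taken from one core cannot be transferred to the other in this pair. Compound 2 already stands at 16%, but whether this low start or some other feature of the core sets the size of the step cannot be told from two pairs, and neither pair says how the change would behave on a third core.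

Open, going by these compounds, is whether a smaller acyl group such as acetyl, or a methyl ether on the same oxygen, would follow benzoyl on either core. Also open, on these data alone, is how the step would read on the second core with a carboxylic acid in place of the ethyl ester.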